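The source may report more compounds than this note shows. Statements on the series, on what has been measured and on what is new or still open speak of the compounds shown alone.

Compound 1 `Cc1cnc(C(=O)Nc2cccc3ccc(C)nc23)cn1` and compound 3 `Cc1ccc2cccc(NC(=O)c3cnccn3)c2n1` share one core and differ only by hydrogen in place of methyl on an aromatic carbon. In a functional assay on MIA PaCa-2 cells (Homo sapiens) for inhibition, read by MTT assay, with a stated time of 72 h (a lower number here means a stronger inhibitor, a higher number a weaker inhibitor), compound 1 gives > 10000 nM, which is a limit of the assay rather than a number. In this assay compound 3 gives > 10000 nM, again a limit. The step that the two limits leave unreadable from compound 1 to compound 3 therefore cannot be sized because of the limit of > 10000 nM in this assay, at which 2 of the 3 values shown sit. Compound 2 `Cc1cnc(C(=O)Nc2ccc(Br)c3cccnc23)cn1` carries a different core; the difference between the two cores is not broken down here. In this assay, going by the values given here, compound 2 gives 2200 nM, the only plain number among the three. Compound 4 `O=C(Nc1ccc(Br)c2cccnc12)c1cnccn1` has not yet been measured and differs from compound 2 by hydrogen in place of methyl on an aromatic carbon, the same change as before. For compound 4 the expected step is a 1.4-fold higher number from compound 2 to compound 4 (0.13 log units; within the scatter), since the earlier matching step could not be read and only compound 2 with 2200 nM anchors the guess. Compound 4 is thus expected near 3000 nM, somewhere between 1000 nM and 10000 nM.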

Compound 4, half-maximal inhibitory concentration: 750 nM
Compound 4: middle estimate off by 4.0-fold (0.60 log units), on the high side; the measured number lies below the stated range.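

In this assay, replacing 5-methylpyrazin-2-yl with pyrazin-2-yl on the core of compound 2 gives a 2.9-fold lower number from compound 2 to compound 4 (0.47 log units; beyond the scatter), a modest gain in strength that lies beyond the usual scatter. Going by these compounds alone, the same change on the core of compound 1 cannot be read, so no second sized step is available for comparison, because both compounds in that pair give only a limit of the assay: the limit of > 10000 nM in this assay, at which 2 of the 4 values shown sit. The gain is therefore shown on one core only, and these results do not show whether it carries over to another core.

The compounds shown leave open whether the gain would appear on a further core. They also leave open how an amine or a longer chain in place of the methyl would read in this assay.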